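Aryl for amidomethyl on the ring nitrogen: compound 4

The compounds below may be only part of what the source reports. "The series", "measured", "known", "first", "only" and "open" are said of these compounds alone.

Measured so far:
compound 1, `CCOC(=O)C1=Cc2ccccc2OC1(OCc1cc(-c2ccc(F)cc2F)no1)C(F)(F)F`: > 150000 nM (a limit of the assay, not a number)
compound 2, `CCOC(=O)C1=Cc2ccccc2OC1(OCc1cn(CC(=O)NC2CCCCC2)nn1)C(F)(F)F`: 11400 nM
compound 3, `O=C(O)C1=Cc2ccccc2OC1(OCc1cc(-c2ccc(F)cc2F)no1)C(F)(F)F`: > 150000 nM (a limit of the assay, not a number)

Among the compounds with values here, in a functional assay on HeLa cells (Homo sapiens) for inhibition, read by MTT assay, with a stated time of 24 h (on this read-out higher numbers stand for weaker inhibition and lower numbers for stronger inhibition), compound 2 gives 11400 nM, the only number in the set. Two of the three values sit at the limit of > 150000 nM in this assay, at which 2 of the 3 values shown sit. Within the data shown here, the one step that can be drawn, a step that the two limits leave unreadable from compound 1 to compound 3, runs between two limits and gives no size, so no measured step bears on the change now in question.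

Compound 4, `CCOC(=O)C1=Cc2ccccc2OC1(OCc1cn(-c2ccc(C)cc2)nn1)C(F)(F)F`, differs from compound 2 by 4-methylphenyl in place of (cyclohexylcarbamoyl)methyl on an aromatic nitrogen. Among the measured compounds shown here, nothing in the measured set tells how this assay responds to a change on that aromatic nitrogen; the cyclohexyl ring and the amide are given up and a methyl-bearing aromatic ring takes their place, with no precedent for either direction.

Compound 4 is therefore expected to stay close to compound 2, the estimate for compound 4 being 15000 nM in this assay, with a range from 3000 nM to 75000 nM. The step this estimate implies, a 1.3-fold higher number from compound 2 to compound 4 (0.12 log units; within the scatter), is expected to lie within the usual scatter, and a limit rather than a number remains possible.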

Compound 4, half-maximal inhibitory concentration: 25100 nM
Compound 4: the middle estimate sits 1.7-fold (0.22 log units) below what was measured; the range from low to high includes it.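

In this assay, within the data shown here, the group on the aromatic nitrogen of the five-membered ring with 3 nitrogen now has a measured effect: 4-methylphenyl in place of (cyclohexylcarbamoyl)methyl gives a 2.2-fold higher number from compound 2 to compound 4 (0.34 log units; beyond the scatter), the first readable step. The step is modest, and compound 4 still returns a number rather than a limit, so on this core neither the amide nor the cyclohexyl ring is required for a measurable read-out at this position. The compounds shown give no measured basis for a cause of this step.

From the compounds shown here alone, the exchange removes the amide, the amide hydrogen and the non-aromatic ring in one move, and it changes the link to the ring nitrogen as well, so the share of each in the step remains open. Also open, going by these compounds, is how the read-out would respond on the same core to an amine on the aromatic ring in place of the methyl, or to a longer chain between the aromatic nitrogen and the cyclohexyl ring.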